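The source may hold more compounds than are shown below. What is called first, only, known or untested is meant among the compounds shown, and "the series" means these compounds.

Compound 1 `C=CC1=C(C(=O)NCCC)C(c2ccc(F)cc2)OC1`: > 100000 nM
Compound 2 `C=CC1=C(C(=O)NCc2ccc(C)cc2)C(c2ccc(F)cc2)OC1`: 62100 nM
Compound 3 `C=CC1=C(C(=O)NC(C)(C)C)C(c2ccc(OC)cc2)OC1`: > 100000 nM

Three compounds built on the same core were tested in a functional assay on QGY7701 cells (Homo sapiens) for cytotoxicity, read by MTT assay, with a stated time of 24 h; a higher number here means a weaker inhibitor, a lower number a stronger inhibitor. Compound 1 reaches only a limit of the assay, > 100000 nM. Compound 3 likewise reaches only a limit, > 100000 nM. Within the data shown here, compound 2 is the single compound with an actual number, 62100 nM, and so it stands alone, the other two sitting at the limit of > 100000 nM in this assay, at which 2 of the 3 values shown sit. Among the measured compounds shown here, the one measured step between neighbouring compounds, an at least 1.6-fold lower number from compound 1 to compound 2 (0.20 log units; that floor lies within the scatter), concerns a change on the chain carbon next to the amide nitrogen, not on the aromatic ring.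

Compound 4 `C=CC1=C(C(=O)NCc2ccc(Cl)cc2)C(c2ccc(F)cc2)OC1` differs from compound 2 by chloro in place of methyl on an aromatic carbon. For the measured compounds named here, no measured step swaps one small group for another on that ring, so there is nothing in these numbers that points in either direction. The step is therefore expected to stay within the scatter: a 1.1-fold lower number from compound 2 to compound 4 (0.05 log units; within the scatter). Compound 4 is expected to give about 55000 nM, somewhere between 20000 nM and 150000 nM, with a real chance that the assay again reports only a limit.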

Compound 4, half-maximal inhibitory concentration: 36900 nM
For compound 4 the middle estimate is 1.5-fold (0.17 log units) above the measured one; low and high end bracket the measured number.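

Replacing methyl with chloro on this aromatic carbon, para to a large group, gives a 1.7-fold lower number from compound 2 to compound 4 (0.23 log units; within the scatter), so in this assay the two compounds cannot be told apart and this position tolerates either group without a change that can be read. The larger comparison is firmer: with 4-chlorophenyl in place of ethyl on the chain carbon bound to the amide nitrogen, there is an at least 2.7-fold lower number from compound 1 to compound 4 (0.43 log units; beyond the scatter). Among these compounds, the earlier step to the 4-methylphenyl group gave only a floor within the scatter, so this is the first evidence that an aromatic group at this end of the amide goes with a lower number than the short chain.

Going by these compounds, whether a carboxylic acid or an amine on the same ring carbon would fit this picture stays open. Compound 3 differs from the others in more than one place, so it cannot show how the tert-butyl amide or the methoxy group contributes on its own.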